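From chloropyridine to chlorothiophene: an estimate for compound 4

A few compounds are considered here, and "the series" means these few. Any claim that something is new, unique, unknown or untested is made for them only; others in the source may bear on it.

Compound 1 `COc1ccccc1-n1nc(C2CC(C)(C)OC(C)(C)C2)cc1-c1ccnc(Cl)c1` was tested in an assay on HEK293 cells for inhibition of Voltage-dependent N-type calcium channel subunit alpha-1B (Homo sapiens), read by patch clamp, using a membrane potential dye (on this read-out higher numbers stand for weaker inhibition and lower numbers for stronger inhibition), and gives 250 nM. Among the two numbers reported it stands lowest. Compound 2 `COc1ccccc1-n1nc(C2CC(C)(C)OC(C)(C)C2)cc1-c1ccc(C)nc1` carries a 6-methylpyridin-3-yl group where compound 1 carries 2-chloropyridin-4-yl; in this assay compound 2 gives 13000 nM, so the step of a 52-fold higher number from compound 1 to compound 2 (1.72 log units; beyond the scatter) is a large weakening. For compound 3 `COc1ccccc1-n1nc([C@@H]2CCO[C@@H](C(C)C)C2)cc1-c1ccc(Cl)cc1` the result in this assay is "not determined" (no result reported).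

Compound 4 `COc1ccccc1-n1nc(C2CC(C)(C)OC(C)(C)C2)cc1-c1csc(Cl)c1` differs from compound 1 in one place: 5-chlorothiophen-3-yl in place of 2-chloropyridin-4-yl on an aromatic carbon. Going by the values given here, the only measured step at this position is a 52-fold higher number from compound 1 to compound 2 (1.72 log units; beyond the scatter), where the ring and the chlorine were altered together; compound 4 keeps a chlorine and changes the ring from six-membered to five-membered, so no step of exactly this kind has been measured. Because compound 2 fell so far with a 52-fold higher number from compound 1 to compound 2 (1.72 log units; beyond the scatter), a change at this position can matter greatly, yet the retained chlorine in compound 4 leaves the size uncertain. For compound 4 a moderate weakening to an estimated 700 nM is expected, within 150 nM to 3500 nM. The expected step is a 2.8-fold higher number from compound 1 to compound 4 (0.45 log units; beyond the scatter).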

Compound 4, half-maximal inhibitory concentration: 28 nM
Compound 4: middle estimate off by 25-fold (1.40 log units), on the high side, and the stated range ends above it.
By their numbers in this assay, from the lowest: compound 4; then compound 1; then compound 2.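

The step (an 8.9-fold lower number from compound 1 to compound 4 (0.95 log units; beyond the scatter)) shows that in this assay a change at this position can also strengthen inhibition, and that a six-membered aromatic ring is not needed here: the five-membered 5-chlorothiophen-3-yl group does better than 2-chloropyridin-4-yl. The step (a 460-fold lower number from compound 2 to compound 4 (2.67 log units; beyond the scatter)) shows how wide the range at this single position now is, with the 5-chlorothiophen-3-yl group far ahead of 6-methylpyridin-3-yl. No measurement on hand explains why the five-membered ring gives the lower number.

Still open, from the compounds shown here alone, is whether the chlorine on the five-membered ring is needed at all. Going by these compounds, it is also open whether a methyl group, a nitrile or an amine in its place would keep the number this low.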